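The compounds below may be only part of what the source reports. "The series", "measured", "known", "first", "only" and "open" are said of these compounds alone.

The study sets three compounds sharing one core side by side, two of them measured and one still awaiting its number. Compound 1, `CNC(=O)N1CC1C#N`, was tested in a functional assay on MCF7 cells (Homo sapiens) for inhibition (on this read-out lower numbers stand for stronger inhibition and higher numbers for weaker inhibition), where compound 1 gives 27000 nM. Compound 2, `N#CC1CN1C(=O)Nc1ccccc1`, gives in this assay a value of 2900 nM. Within the data shown here, of the two numbers known so far, that of compound 1 is the higher; compound 2 carries the lower value, and the gap between the two lies beyond the usual scatter. Compound 3, `N#CC1CN1C(N)=O`, differs from compound 1 in one place: hydrogen in place of methyl on an amide-type nitrogen. Among the measured compounds shown here, no pair of measured compounds separated by exactly this change has been recorded, so the effect must be judged from what the two known values show. Because compound 2 gives 2900 nM with a different group on the same amide-type nitrogen while compound 1 gives 27000 nM, removing the methyl is expected to weaken inhibition slightly rather than strengthen it, by a step near the edge of the scatter. For compound 3 the step expected is a 1.5-fold higher number from compound 1 to compound 3 (0.17 log units; within the scatter). Compound 3 is therefore expected to give about 40000 nM, within a range from 15000 nM to 110000 nM.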

Compound 3, half-maximal inhibitory concentration: > 54000 nM
Compound 3 gave a limit, no number (the forecaster's own chance of this, stated with the estimate: 15%); middle value at least 1.3-fold (0.13 log units) away from the limit.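

In this assay, compound 3 yields a limit and not a number: the limit of > 54000 nM in this assay, at which 1 of the 3 values shown sits. Even so, this gives the first direct reading at the amide-type nitrogen, where the earlier compounds offered no pair separated by a single recorded step: hydrogen in place of methyl gives an at least 2.0-fold higher number from compound 1 to compound 3 (0.30 log units; that floor lies within the scatter). The direction of the change is therefore constrained, since taking away the methyl brings no gain in inhibition, but the printed floor of the step lies within the scatter, so on its own it does not establish a real loss.

The compounds shown leave open where the true value of compound 3 lies, and with it the full size of this step, which could turn out small or considerably larger. They also leave open how an ethyl group, a longer alkyl chain or a chain ending in an amine on the same amide-type nitrogen would read in this assay, and so whether the response to growing this substituent from hydrogen through methyl continues in a steady way.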